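Swapping a sulfonyl cap for a carbamate on the pyrrolidine

The compounds below may be only part of what the source reports. "The series", "measured", "known", "first", "only" and "open" are said of these compounds alone.

Three compounds sharing one core were tested in a functional assay on HCC827 cells (Homo sapiens) for antiproliferative activity, read by MTT assay, with a stated time of 72 h; a lower number here means a stronger inhibitor, a higher number a weaker inhibitor. Compound 1 `CN1CCN(c2ccc(Nc3ncc4nc(Nc5ccccc5)n([C@H]5CCN(C(=O)OC(C)(C)C)C5)c4n3)cc2)CC1` gives 110 nM in this assay. Compound 2 `CN1CCN(c2ccc(Nc3ncc4nc(Nc5ccccc5)n([C@H]5CCNC5)c4n3)cc2)CC1`, which bears a bare ring amine, gives 530 nM; the step of a 4.8-fold higher number from compound 1 to compound 2 (0.68 log units; beyond the scatter) is modest. Compound 3 `CN1CCN(c2ccc(Nc3ncc4nc(Nc5ccccc5)n([C@@H]5CCN(S(=O)(=O)C6CC6)C5)c4n3)cc2)CC1` gives 0.88 nM and stands lowest of the three numbers, with the steps of a 130-fold lower number from compound 1 to compound 3 (2.10 log units; beyond the scatter) and a 600-fold lower number from compound 2 to compound 3 (2.78 log units; beyond the scatter) both large and well beyond the scatter.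

Compound 4 `CN1CCN(c2ccc(Nc3ncc4nc(Nc5ccccc5)n([C@@H]5CCN(C(=O)OC(C)(C)C)C5)c4n3)cc2)CC1` is not yet measured. Its change from compound 3 is tert-butoxycarbonyl in place of cyclopropylsulfonyl on an amine nitrogen in a ring, so compound 4 carries the same tert-butoxycarbonyl group as compound 1. The step that bears most directly on this change is a 130-fold lower number from compound 1 to compound 3 (2.10 log units; beyond the scatter), which ran in the opposite direction; reversing it suggests compound 4 should give a clearly higher number than compound 3 in this assay, with the cyclopropylsulfonyl group removed. Compound 1 itself, which is not an exact mirror of this change, gives 110 nM and anchors the expectation.

Compound 4 is therefore expected to show the step of a 57-fold higher number from compound 3 to compound 4 (1.75 log units; beyond the scatter) in this assay, a large rise. The estimated value for compound 4 is 50 nM, within a range from 8 nM to 300 nM.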

Compound 4, half-maximal inhibitory concentration: 12 nM
The estimate for compound 4 lay 4.2-fold (0.62 log units) above the measured number; low and high end bracket the measured number.
By their numbers in this assay, from the lowest: compound 3; then compound 4; then compound 1; then compound 2.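

Compound 4 separates two changes that were combined in the earlier comparison of compound 1 with compound 3, which differ in both the cap on the ring nitrogen and the configuration at the ring carbon. With the configuration held constant in this assay, replacing cyclopropylsulfonyl with tert-butoxycarbonyl alone gives a 14-fold higher number from compound 3 to compound 4 (1.13 log units; beyond the scatter), so the cap matters at this position, and the stereocentre matters as well, since a 9.2-fold lower number from compound 1 to compound 4 (0.96 log units; beyond the scatter) can be assigned to configuration alone because of one structural fact: the fact that compounds 1 and 4 differ only in the configuration as drawn. The remaining step, a 44-fold lower number from compound 2 to compound 4 (1.65 log units; beyond the scatter), cannot be read as the effect of the cap alone, as compound 2 shares the drawn ring configuration of compound 1 and the step therefore includes the change of configuration too.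

The compounds shown leave open whether the preference between the two caps holds in the configuration of compound 1, and how a bare ring amine behaves in the configuration of compound 4. They also leave open whether the sulfonyl part or the cyclopropyl ring of the better cap carries its advantage, a question that a methylsulfonyl or an acetyl group on the same nitrogen could address.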